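Aryl Urea Swap on a Longer Amine Chain

The source may hold more compounds than are shown below. What is called first, only, known or untested is meant among the compounds shown, and "the series" means these compounds.

Compound 1 `CN(C)CCn1cnnc1-c1cc(Oc2ccc(NC(=O)Nc3ccc(F)c(Cl)c3)cc2F)ccn1`: 8320 nM
Compound 2 `CN(C)CCn1cnnc1-c1cc(Oc2ccc(NC(=O)Nc3ccc(Cl)cc3Cl)cc2F)ccn1`: 7960 nM
Compound 3 `CN(C)CCCn1cnnc1-c1cc(Oc2ccc(NC(=O)Nc3ccc(F)c(Cl)c3)cc2F)ccn1`: 14200 nM

All three were tested in a functional assay on MDA-MB-231 cells (Homo sapiens) for antiproliferative activity, read by MTT assay, with a stated time of 72 h; a lower number here means a stronger inhibitor, a higher number a weaker inhibitor. Compound 1 and compound 2 share a core and differ only by 2,4-dichlorophenyl in place of 3-chloro-4-fluorophenyl on an amide-type nitrogen; that change gave a 1.0-fold lower number from compound 1 to compound 2 (0.02 log units; within the scatter). Compound 1 and compound 3 differ in the core by (dimethylamino)methyl in place of dimethylamino on a saturated chain carbon, two bonds along the chain from an aromatic nitrogen, a step of a 1.7-fold higher number from compound 1 to compound 3 (0.23 log units; within the scatter).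

Compound 4 `CN(C)CCCn1cnnc1-c1cc(Oc2ccc(NC(=O)Nc3ccc(Cl)cc3Cl)cc2F)ccn1` is not yet measured. It differs from compound 3 by 2,4-dichlorophenyl in place of 3-chloro-4-fluorophenyl on an amide-type nitrogen, the same change as from compound 1 to compound 2, made at the same place. Because that earlier step was a 1.0-fold lower number from compound 1 to compound 2 (0.02 log units; within the scatter), a similar step is expected here, namely a 1.0-fold lower number from compound 3 to compound 4 (0.02 log units; within the scatter). Compound 4 is therefore estimated at 13600 nM in this assay, with a likely range from 6000 nM to 30000 nM.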

Compound 4, half-maximal inhibitory concentration: 7490 nM
Compound 4: middle estimate off by 1.8-fold (0.26 log units), on the high side, and the stated range covers the measured number.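

In this assay, the aryl swap gave a 1.9-fold lower number from compound 3 to compound 4 (0.28 log units; within the scatter), while lengthening the amine chain with the 2,4-dichlorophenyl group in place gave a 1.1-fold lower number from compound 2 to compound 4 (0.03 log units; within the scatter). Each change behaved alike on both cores, starting with the aryl swap: the same change on two cores in this assay, a 1.0-fold lower number (0.02 log units; within the scatter) from compound 1 to compound 2 and a 1.9-fold lower number (0.28 log units; within the scatter) from compound 3 to compound 4, 1.8-fold (0.26 log units) apart, within the scatter of two such steps

The chain change agrees too, but every step here lies within the scatter, so this shows only that small steps stayed small, not that a change with a clear effect would carry over: the same change on two cores in this assay, a 1.7-fold higher number (0.23 log units; within the scatter) from compound 1 to compound 3 and a 1.1-fold lower number (0.03 log units; within the scatter) from compound 2 to compound 4, 1.8-fold (0.26 log units) apart, within the scatter of two such steps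

Still open, going by these compounds, is whether a phenyl bearing trifluoromethyl on the amide-type nitrogen, a longer chain, or morpholine in place of dimethylamino would give a clear step. Whether such a step would then carry across cores is also unknown.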